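The source may hold more compounds than are shown below. What is called first, only, known or untested is meant among the compounds shown, and "the series" means these compounds.

Working notes on the series so far. In a functional assay on NUGC-3 cells (Homo sapiens) for antiproliferative activity, read by sulforhodamine B assay (on this read-out higher numbers stand for weaker inhibition of growth and lower numbers for stronger inhibition of growth), compound 1 `COc1cccc(OCCC(C)(C)C)c1C(=O)/C=C/c1ccc(O)cc1` gives > 30000 nM, which is a limit and not a number. Compound 2 `CC(C)=CCOc1cccc(O)c1C(=O)/C=C/c1ccc(O)cc1` gives > 30000 nM, again a limit. Compound 3 `O=C(/C=C/c1ccc(O)cc1)c1c(O)cccc1OCC1CCCCC1` gives > 30000 nM, also a limit, so compound 3 has no number of its own. The whole picture in this assay is thus (the limit of > 30000 nM in this assay, at which 3 of the 3 values shown sit).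

Compound 4 `O=C(/C=C/c1ccc(O)cc1)c1c(O)cccc1OCc1ccccc1` is the next to be read. It differs from compound 3 by one change, phenyl in place of cyclohexyl on a saturated chain carbon bound to an oxygen on an aromatic ring, so that cyclohexylmethoxy becomes benzyloxy.

For the measured compounds named here, the one measured step at this place is a step that the two limits leave unreadable from compound 2 to compound 3. From the compounds shown here alone, it offers no size to carry over, and the direction of any change at this place remains open. The expectation therefore rests on compound 3, whose limit is > 30000 nM. The expected step is a number no higher from compound 3 to compound 4 (the limit leaves the size open), which means none beyond the scatter, and a further limit is the likeliest report. For compound 4 the estimated value is 30000 nM, with an expected range from 10000 nM to 60000 nM.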

Compound 4, concentration for 50% growth inhibition: > 30000 nM
Compound 4 ended at the assay's limit (the forecaster's own chance of this, stated with the estimate: 70%); the middle value sits exactly at the limit.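

Neither the step from compound 3 to compound 4 nor the step from compound 2 to compound 4 can be read, as each pair holds only limits: the limit of > 30000 nM in this assay, at which 4 of the 4 values shown sit.

The compounds shown leave open whether cyclohexyl, phenyl or 2-methylprop-1-en-1-yl at this place differ at all in growth inhibition, as no compound here has a number of its own.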